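Solubility notes on a lengthened diamine side chain

This account rests on a few compounds, and the source may have more. Where it says the series, first, only, none or still open, it means among the compounds named here.

Compound 3 `CCOc1ccc2c(NCCN(C)C)ccnc2c1` stands at the upper limit of a physicochemical assay for solubility; a lower number here means a less soluble compound, a higher number a more soluble compound: in this assay compound 3 gives > 10000 ug/mL, a limit rather than a number. Compound 1 `C=CCOc1ccc2c(NCCN(C)C)ccnc2c1` gives > 10000 ug/mL in this assay, likewise a limit. Compound 2 `CN(C)CCCNc1ccnc2cc(OCc3ccc(F)cc3)ccc12` gives > 10000 ug/mL in this assay, also a limit. Compound 4 `CCOc1ccc2c(NCCCN(C)C)ccnc2c1` differs from compound 3 by (dimethylamino)methyl in place of dimethylamino on a saturated chain carbon, two bonds along the chain from a nitrogen on an aromatic ring. Among the compounds with values here, the only measured step, a step that the two limits leave unreadable from compound 1 to compound 3, sits between two limits and cannot be sized, and no measured pair alters the chain between the two nitrogens, so nothing bears directly on this change. Given (the limit of > 10000 ug/mL in this assay, at which 3 of the 3 values shown sit), compound 4 is expected to remain at the limit, with a number no higher from compound 3 to compound 4 (the limit leaves the size open) estimated as no step beyond the scatter. The estimate for compound 4 is 10000 ug/mL, range 3000 ug/mL to 30000 ug/mL.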

Compound 4, solubility: > 10000 ug/mL
Compound 4 was reported as a limit (the forecaster's own chance of this, stated with the estimate: 80%); the middle value lies on the limit itself.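

In this assay, within the data shown here, compound 4 gives > 10000 ug/mL, a limit, so no step from compound 2 or compound 3 to compound 4 can be read: the limit of > 10000 ug/mL in this assay, at which 4 of the 4 values shown sit. The compounds shown leave open how the solubilities of compound 1, compound 2, compound 3 and compound 4 compare.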